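A few compounds are considered here, and "the series" means these few. Any claim that something is new, unique, unknown or untested is made for them only; others in the source may bear on it.

Three compounds have been measured in a functional assay on THP-1 cells (Homo sapiens) for inhibition, read by sulforhodamine B assay, with a stated time of 48 h, tested at 50 uM; a lower number here means less inhibition of growth, a higher number more inhibition of growth at the concentration tested:

Compound 1, `COc1cc(/C=C/C(=O)/C=C/c2ccccc2)ccc1OCc1cn(CCCOc2cc(=O)oc3ccccc23)nn1`, gives 48%.
Compound 2, `COc1cc(/C=C/C(=O)/C=C/c2ccco2)ccc1OCc1cn(CCCCOc2cc(=O)oc3ccccc23)nn1`, gives 49%.
Compound 3, `COc1cccc(/C=C/C(=O)/C=C/c2ccc(OCc3cn(CCCCOc4cc(=O)oc5ccccc45)nn3)c(OC)c2)c1`, gives 47%.

Compound 3 holds the lowest of the three numbers, but its nearest neighbour is compound 1, only marginally higher, and even compound 2 sits within the scatter of it, so the three compounds cannot be told apart in this assay.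

Compound 4, `COc1cc(/C=C/C(=O)/C=C/c2cccs2)ccc1OCc1cn(CCCCOc2cc(=O)oc3ccccc23)nn1`, has not yet been measured. It differs from compound 3 in one place: thiophen-2-yl in place of 3-methoxyphenyl on a double-bonded chain carbon bound to a double-bonded chain carbon.

Among the compounds with values here, one measured step bears on this change. Going from the furan-2-yl compound to the 3-methoxyphenyl compound gave a number 2 percentage points lower from compound 2 to compound 3 (within the scatter), a change that stays within the scatter. Swapping that same position back to a five-membered aromatic ring with one hetero atom, now thiophen-2-yl, is therefore expected to move the number by no more than the scatter in either direction. The step from compound 3 to compound 4 is estimated at a number 1 percentage points higher from compound 3 to compound 4 (within the scatter).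

Compound 4 is thus expected to give about 48% in this assay, with a likely range from 38% to 58%.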

Compound 4, percent growth inhibition at one concentration: 44%
Compound 4: the middle estimate sits 4 percentage points above what was measured; the measured number falls inside the stated range.
By their numbers in this assay, from the lowest: compounds 4, 3, 1 and 2 (each within the scatter of the next).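

In this assay, a third aromatic group now stands on a double-bonded chain carbon bound to a double-bonded chain carbon, and replacing 3-methoxyphenyl with thiophen-2-yl gives a number 3 percentage points lower from compound 3 to compound 4 (within the scatter) at this place. Replacing furan-2-yl with thiophen-2-yl gives a number 5 percentage points lower from compound 2 to compound 4 (within the scatter) here, so even the largest of the steps seen at this place stays within the scatter, and this holds for a six-membered aromatic ring of carbon only and for both five-membered groups. The result gives no reason for this insensitivity, as no measurement bearing on it is available.

The compounds shown carry only aromatic groups at this place, so it remains open whether an amine or a carboxylic acid there would move the number beyond the scatter. Every number also comes from a single concentration on one cell type, which leaves open whether these compounds would still be indistinguishable at other concentrations.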